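A few compounds are considered here, and "the series" means these few. Any claim that something is new, unique, unknown or untested is made for them only; others in the source may bear on it.

- Compound 1 `c1ccc(-c2nc3cc[nH]cc-3n2)cc1`: > 100000 nM, a limit
- Compound 2 `c1ccc(-c2nc3ccn(CC4CCCCC4)cc-3n2)cc1`: > 100000 nM, a limit
- Compound 3 `c1ccc(-c2nc3ccn(Cc4ccccn4)cc-3n2)cc1`: not yet measured

In an ADME assay on MDBK cells (Bos taurus) for cytotoxicity (a lower number here means that less compound is tolerated, a higher number that more compound is tolerated), compound 2 reports only a limit, > 100000 nM. It therefore has no number of its own, and its value sits with that of compound 1 at the same ceiling: the limit of > 100000 nM in this assay, at which 2 of the 2 values shown sit.

The change to compound 3 is pyridin-2-yl in place of cyclohexyl on a saturated chain carbon bound to an aromatic nitrogen. In words, cyclohexylmethyl gives way to (pyridin-2-yl)methyl. Within the data shown here, the one measured step that bears on this is a step that the two limits leave unreadable from compound 1 to compound 2. That step touches the same place on the core but offers no size to carry over. No step beyond the scatter is therefore expected in this assay, and a further limit is the likeliest report. The expected step is a number no higher from compound 2 to compound 3 (the limit leaves the size open). Compound 3 is estimated at 100000 nM, with an expected range of 50000 nM to 200000 nM.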

Compound 3, half-maximal cytotoxic concentration: > 100000 nM
Compound 3: no number, only a limit (the forecaster's own chance of this, stated with the estimate: 85%); the middle value lies on the limit itself.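

Compound 3 reports only a limit, > 100000 nM. Among these compounds, no step among compound 1, compound 2 and compound 3 can be read in this assay, as all three sit at the same ceiling: the limit of > 100000 nM in this assay, at which 3 of the 3 values shown sit. The compounds shown leave open whether any substituent on the aromatic nitrogen changes the half-maximal cytotoxic concentration at all.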